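Shorter chain and bare cyanoguanidine on the shared core

The source may hold more compounds than are shown below. What is called first, only, known or untested is meant among the compounds shown, and "the series" means these compounds.

Compound 1 `C/N=C(/NC#N)NCCCCCCn1nc(-c2ccccc2)ccc1=O`: > 100 mg/kg
Compound 2 `CC/N=C(/NC#N)NCCCCn1nc(-c2ccccc2)cc(C)c1=O`: 100 mg/kg
Compound 3 `NC(=O)SCCCCCN1NC=CC=C1c1ccccc1`: 23.8 mg/kg

Within the data shown here, in a functional assay on the whole organism (stomach) with Rattus norvegicus as the target (on this read-out lower numbers stand for an effect already at smaller amounts and higher numbers for an effect only at larger amounts of compound), compound 1 gives > 100 mg/kg, which is a limit of the assay and not a number; this is the one value that sits at the limit of > 100 mg/kg in this assay, at which 1 of the 3 values shown sits. In this assay compound 2 gives 100 mg/kg. Compound 3 gives 23.8 mg/kg in this assay. Compound 4 `N#CNC(=N)NCCCCCn1nc(-c2ccccc2)ccc1=O` differs from compound 1 by a group of 6 heavy atoms (2 carbon, 4 nitrogen; no ring) in place of a group of 8 heavy atoms (4 carbon, 4 nitrogen; no ring), on a saturated chain carbon, five bonds along the chain from an aromatic nitrogen. No measured step links any two of these compounds, so the size of this step is open; since the value of compound 1 is only a limit, the expectation is a dose for compound 4 that is smaller by no more than a little beyond the scatter, or unchanged. Compound 4 is therefore expected to give 80 mg/kg in this assay, between 30 mg/kg and 250 mg/kg. The expected step is an at least 1.2-fold lower number from compound 1 to compound 4 (0.09 log units; that floor lies within the scatter).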

Compound 4, dose for half-maximal effect: > 100 mg/kg
Compound 4 gave a limit, no number (the forecaster's own chance of this, stated with the estimate: 40%); middle value at least 1.2-fold (0.09 log units) from the limit.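

In this assay, among these compounds, compound 1 and compound 4 both sit at a limit, so no step between them can be read: the limit of > 100 mg/kg in this assay, at which 2 of the 4 values shown sit.

The compounds shown leave open whether the group of 6 heavy atoms in place of the group of 8 heavy atoms changes the dose at all.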